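The compounds below may be only part of what the source reports. "The series", "measured", "known", "first", "only" and "open" are said of these compounds alone.

Measured so far in a functional assay on HEK293 cells for agonist activity at Toll-like receptor 2 (Homo sapiens), read by reporter gene assay, with a stated time of 12 h; on this read-out higher numbers stand for an effect only at larger amounts of compound and lower numbers for an effect already at smaller amounts:
compound 1 `CCCCCCCCCCCCCCCCCC(=O)OCCSC[C@H](N)C(=O)N[C@@H](CO)C(=O)OC` gives 4.79 nM
compound 2 `CCCCCCCCCCCCCCCC(=O)OCCSC[C@H](NC(C)=O)C(=O)N[C@@H](CO)C(=O)OC` gives 1.01 nM
compound 3 `CCCCCCCCCCCCCCCC(=O)OCCSC[C@H](NC(=O)CCC)C(=O)N[C@@H](CO)C(=O)OC` gives 1.64 nM

Compound 3 stands second highest of the three numbers. For the measured compounds named here, its nearest neighbour is compound 2, and the gap between them is within the scatter; this is the one measured step that differs in a single place, a 1.6-fold higher number from compound 2 to compound 3 (0.21 log units; within the scatter), where the change is ethyl in place of hydrogen on a saturated chain carbon bound to a carbonyl carbon. Compound 1 differs from compound 3 in more than one place, and the gap between their two values is beyond the scatter.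

Compound 4 `CCCCCCCCCCCCCCCC(=O)OCCSC[C@H](NC(=O)C(F)(F)F)C(=O)N[C@@H](CO)C(=O)OC` is not yet measured. Relative to compound 3 the change is trifluoromethyl in place of propyl on a carbonyl carbon. Going by the values given here, the only measured step bearing on this position, a 1.6-fold higher number from compound 2 to compound 3 (0.21 log units; within the scatter), shows that lengthening the chain on the carbonyl carbon left the number within the scatter. Among the compounds with values here, no measured compound carries fluorine on that carbonyl carbon, so the data give no direction for the present change. The step to compound 4 is therefore expected to be small, with a range that allows a moderate shift either way. For compound 4 in this assay the estimate is 2 nM, expected to lie between 0.8 nM and 6 nM. This amounts to an expected step of a 1.2-fold higher number from compound 3 to compound 4 (0.09 log units; within the scatter).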

Compound 4, half-maximal effective concentration: 4.5 nM
For compound 4 the middle estimate is 2.3-fold (0.35 log units) below the measured one, within the range that was stated.
By their numbers in this assay, from the lowest: compounds 2 and 3 (each within the scatter of the next); then compounds 4 and 1 (each within the scatter of the next).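

In this assay the group on the carbonyl carbon bound to the amide-type nitrogen does affect the number: trifluoromethyl in place of propyl gives a 2.7-fold higher number from compound 3 to compound 4 (0.44 log units; beyond the scatter) and trifluoromethyl in place of methyl gives a 4.5-fold higher number from compound 2 to compound 4 (0.65 log units; beyond the scatter), both modest and both beyond the scatter. Methyl and propyl, by contrast, lie within the scatter of each other, with a 1.6-fold higher number from compound 2 to compound 3 (0.21 log units; within the scatter), so among compounds 2, 3 and 4 only the trifluoromethyl compound stands apart, and none of the three goes against this reading. Nothing available on these compounds explains the difference.

Still open, as far as these compounds go, is whether the shift follows the number of fluorine atoms or holds for fluorinated groups generally, which a monofluoromethyl, a difluoromethyl or a pentafluoroethyl group on the same carbonyl carbon would test, while a chain longer than propyl or a benzoyl group in place of the whole acyl unit would show how far the tolerance for plain carbon groups extends. Compound 1 differs from compounds 2, 3 and 4 in more than one place, so the effect of a free amine at this nitrogen can only be read against a free amine carrying the same ester chain as those three.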